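A few compounds are considered here, and "the series" means these few. Any claim that something is new, unique, unknown or untested is made for them only; others in the source may bear on it.

Measured compounds and their values in a functional assay on MCF7 cells (Homo sapiens) for antiproliferative activity, read by MTT assay, with a stated time of 24 h; on this read-out higher numbers stand for weaker inhibition and lower numbers for stronger inhibition:

Compound 1 `COc1ccc(-c2noc(-c3ccccc3)n2)cc1OC1CCCC1` sits at the limit of this assay, > 1000000 nM.
Compound 2 `COc1ccc(-c2noc(-c3cccnc3)n2)cc1OC1CCCC1` also sits at the limit, > 1000000 nM.
Compound 3 `COc1ccc(-c2noc(-c3ccc(Cl)cc3)n2)cc1OC1CCCC1` gives 174000 nM.

Compound 1 therefore stands at the top of the numbers shown, as a limit rather than a measured value, a position it shares with one other compound (the limit of > 1000000 nM in this assay, at which 2 of the 3 values shown sit). The change to compound 4 `COc1ccc(-c2noc(-c3ccc(O)cc3)n2)cc1OC1CCCC1` is hydroxy in place of hydrogen on an aromatic carbon.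

Within the data shown here, two measured steps bear on it. The closest is the one in which chloro replaces hydrogen on the same aromatic carbon, which gave an at least 5.7-fold lower number from compound 1 to compound 3 (0.75 log units; beyond the scatter). The step to compound 2, pyridin-3-yl in place of phenyl, remains unreadable, a step that the two limits leave unreadable from compound 1 to compound 2. Hydroxy is a different group from chloro, so the chloro step is a guide to direction more than to size. A lowering of the number beyond the scatter is expected, though a limit remains possible.

The estimate for compound 4 in this assay is 300000 nM, between 60000 nM and 1500000 nM, which is expected to mean an at least 3.3-fold lower number from compound 1 to compound 4 (0.52 log units; beyond the scatter).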

Compound 4, half-maximal inhibitory concentration: 390 nM
The estimate for compound 4 lay 770-fold (2.89 log units) above the measured number, outside the stated range (below it).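

In this assay, the aromatic carbon para to a large group proves far more sensitive to the choice of group than the chloro step alone had shown, with hydroxy in place of hydrogen giving an at least 2500-fold lower number from compound 1 to compound 4 (3.40 log units; beyond the scatter). At that same carbon, hydroxy in place of chloro gives a 450-fold lower number from compound 3 to compound 4 (2.65 log units; beyond the scatter), so the modest gain seen with chloro did not mark how much this position can deliver. Replacing pyridin-3-yl with 4-hydroxyphenyl gives an at least 2500-fold lower number from compound 2 to compound 4 (3.40 log units; beyond the scatter), and this step and the one from the phenyl compound are bounds rather than sizes: the limit of > 1000000 nM in this assay, at which 2 of the 4 values shown sit.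

Going by these compounds, whether a methoxy group, an amine or a carboxylic acid at this carbon would match hydroxy remains open. On these data alone, how the number would respond to hydroxy on another carbon of that ring also remains open.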